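The source may report more compounds than this note shows. Statements on the series, on what has been measured and on what is new or still open speak of the compounds shown alone.

Going by the values given here, compound 2 `Cc1ccc(OCC(=O)N(Cc2cccs2)c2ccn[nH]2)cc1` stands at the low end of the two numbers measured so far: in an assay on HEK293 cells for agonist activity at transient receptor potential cation channel subfamily M member 8 (Homo sapiens), read by fluorescence and calcium flux, with a stated time of 15 min (a higher number here means that more compound is needed for the effect, a lower number that less compound is needed), compound 2 gives 0.2 nM, while compound 1 `Cc1ccc(OCC(=O)N(Cc2cccs2)c2cccnc2)cc1` gives 198 nM. Among the compounds with values here, the only step measured, a 990-fold lower number from compound 1 to compound 2 (3.00 log units; beyond the scatter), joins these two, and it is the sole precedent for changing the aromatic group on the amide-type nitrogen while the rest of the shared core is kept.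

Compound 3 `Cc1ccc(OCC(=O)N(Cc2cccs2)c2ccon2)cc1` carries the next change at the same place: 1,2-oxazol-3-yl in place of 1H-pyrazol-5-yl on an amide-type nitrogen. Within the data shown here, this step has no direct counterpart among the measured pairs; the step from compound 1 to compound 2 shows only that the identity of the ring on that nitrogen can move the number over a very wide span, so a change of the ring beyond the scatter is plausible here in either direction. Since compound 2 already holds the lowest number, a move upward from compound 2 to compound 3 is expected rather than a further drop, with wide uncertainty. For compound 3 in this assay an estimate of 4 nM is taken, within 0.4 nM to 40 nM, which corresponds to an expected step of a 20-fold higher number from compound 2 to compound 3 (1.30 log units; beyond the scatter).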

Compound 3, half-maximal effective concentration: 2 nM
Estimate against measurement, compound 3: 2.0-fold (0.30 log units) above, and the stated range covers the measured number.
By their numbers in this assay, from the lowest: compound 2; then compound 3; then compound 1.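

In this assay, going by these compounds alone, there is a 10-fold higher number from compound 2 to compound 3 (1.00 log units; beyond the scatter) and this is the first reading of one five-membered aromatic ring exchanged for another on the amide-type nitrogen, so the number stays sensitive to the ring even when the heavy-atom count of the group does not change. The entering 1,2-oxazol-3-yl has 0 hydrogen-bond donors against 1 for the leaving 1H-pyrazol-5-yl, yet there is still a 99-fold lower number from compound 1 to compound 3 (2.00 log units; beyond the scatter) and so, among these three compounds, both five-membered rings give lower numbers than pyridin-3-yl, and a low number at this position does not depend on having a hydrogen-bond donor in the ring. No supporting data are available to explain either step.

The compounds shown do not separate the loss of the ring hydrogen from the exchange of a ring nitrogen for oxygen, a question that a methyl group on the ring nitrogen bearing that hydrogen in 1H-pyrazol-5-yl would address. On these data alone, it also remains open whether the same order of the three rings holds when another part of the shared core is changed.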